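Naphthyl Added to a Benzamide Series Without Measured Cytotoxicity

This account rests on a few compounds, and the source may have more. Where it says the series, first, only, none or still open, it means among the compounds named here.

Compound 1, `CC(C)N(Cc1cccc(OCCCCCC(=O)O)c1)C(=O)c1ccc(-c2cccc(N(C)C)c2)cc1`, gives > 26000 nM in an ADME assay on HEK293 cells (Homo sapiens) for cytotoxicity, read by CellTiter-Glo and resazurin assay, with a stated time of 72 h (a lower number here means that less compound is needed, a higher number that more compound is needed for the effect), which is a limit of the assay rather than a number.
Compound 2, `CC(C)N(Cc1cccc(OCCCCCC(=O)O)c1)C(=O)c1ccccc1`, gives > 26000 nM in this assay, again only a limit.

Going by the values given here, compound 2 therefore stands at the limit of this assay, and so does the one other value; both sit at the limit of > 26000 nM in this assay, at which 2 of the 2 values shown sit. The step that the two limits leave unreadable from compound 1 to compound 2 cannot be sized. Neither end of it is a real number.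

Compound 3, `CC(C)N(Cc1cccc(OCCCCCC(=O)O)c1)C(=O)c1ccc(-c2cccc3ccccc23)cc1`, differs from compound 2 by naphthalen-1-yl in place of hydrogen on an aromatic carbon. Among the compounds with values here, the only measured step bears on this change in a loose way: it shows that a sizeable aromatic group on the same aromatic carbon in compound 1, and its removal in compound 2, both left the value at the limit. A further aromatic group is therefore expected to give no readable step in this assay, so the expected step is a step that the limit leaves unreadable from compound 2 to compound 3. For compound 3 the estimate in this assay is 30000 nM, with a range from 12000 nM to 80000 nM, and most likely the assay would again report only a limit.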

Compound 3, half-maximal effective concentration: > 26000 nM
Compound 3: no number, only a limit; the forecaster's own chance of this, stated with the estimate: 75%; the middle value does not contradict the limit.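

Compound 3 gives > 26000 nM in this assay, which is again a limit of the assay and not a number. Going by these compounds alone, no step from compound 1 or compound 2 to compound 3 can therefore be read. The compounds shown leave open the concentration at which any of them reaches the half-maximal effect, and so whether changing the group on this aromatic carbon matters at all: the limit of > 26000 nM in this assay, at which 3 of the 3 values shown sit.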